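The source may hold more compounds than are shown below. What is called first, only, known or untested is meant among the compounds shown, and "the series" means these compounds.

Compound 1 `COc1ccc([C@H]2CC(=O)N(c3cc(N)cc(F)c3)C2)cc1OC1CCCC1`, compound 2 `COc1ccc([C@H]2CC(=O)N(c3cccnc3)C2)cc1OC1CCCC1` and compound 3 `COc1ccc([C@H]2CC(=O)N(c3cccc(NCC4CCOC4)c3)C2)cc1OC1CCCC1` share one core and differ only in the group on the amide-type nitrogen in the ring. In a functional assay on HEK293 cells (Homo sapiens) for cytotoxicity (on this read-out higher numbers stand for lower toxicity in this test and lower numbers for higher toxicity in this test), compound 1 gives only a limit of the assay, > 10000 nM. Compound 2 likewise gives a limit, > 10000 nM. Compound 3 also gives a limit, > 10000 nM. Among the measured compounds shown here, the single one-place step, a step that the two limits leave unreadable from compound 1 to compound 2, is therefore unreadable, as the limit of > 10000 nM in this assay, at which 3 of the 3 values shown sit, shows. Compound 4 `COc1ccc([C@H]2CC(=O)N(c3cccc(NS(=O)(=O)c4cc(Br)c(Cl)s4)c3)C2)cc1OC1CCCC1` differs from compound 3 by (4-bromo-5-chlorothiophen-2-yl)sulfonyl in place of (oxolan-3-yl)methyl on a nitrogen on an aromatic ring. For the measured compounds named here, no measured step bears on this change, and the three limits give no direction. Compound 4 is expected to give about 15000 nM, between 5000 nM and 50000 nM. The expected step that the limit leaves unreadable from compound 3 to compound 4 would most likely again be hidden behind a limit.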

Compound 4, half-maximal cytotoxic concentration: > 10000 nM
Compound 4 gave a limit, no number; the forecaster's own chance of this, stated with the estimate: 70%; the middle value does not contradict the limit.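

The step from compound 3 to compound 4 cannot be read, since both compounds give only a limit: the limit of > 10000 nM in this assay, at which 4 of the 4 values shown sit. The compounds shown leave open whether any group on the shared core changes the outcome in this assay.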